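The source may report more compounds than this note shows. Statements on the series, on what has been measured and on what is new or still open speak of the compounds shown alone.

Measured so far:

Compound 1, `ClCc1ccccc1Cn1cnc2c(Cl)ncnc21`, in a functional assay on SK-MEL-5 cells (Homo sapiens) for cytotoxicity, read by sulforhodamine B assay, with a stated time of 48 h (a lower number here means a stronger inhibitor of growth, a higher number a weaker inhibitor of growth), compound 1 gives 2880 nM.
Compound 2, `ClCc1ccccc1Cn1cnc2ncnc(Cl)c21`, in this assay compound 2 gives 4070 nM.

Within the data shown here, of these two numbers, the one for compound 2 is the higher, but its gap to compound 1 lies within the usual scatter of repeated measurements, so the two readings cannot be told apart and neither compound can be called the stronger inhibitor.

The next compound, compound 3, is `ClCc1ccccc1Cn1cnc2nc(Cl)nc(Cl)c21`. Compared with compound 2 the change is chloro in place of hydrogen on an aromatic carbon, a chloro in place of hydrogen on an aromatic carbon of the shared core. Among the measured compounds shown here, no pair of measured compounds shows this same change, so there is no measured step to scale from, and the two numbers in hand only say that a shift of the chloro from one position to another left the reading within scatter.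

On that basis the expected step, a 1.4-fold lower number from compound 2 to compound 3 (0.13 log units; within the scatter), is small and its direction is uncertain. Compound 3 is therefore estimated at about 3000 nM, with a range from 1000 nM to 9000 nM, pending the measurement.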

Compound 3, concentration for total growth inhibition: 2180 nM
Beside the measured number, compound 3's estimate is 1.4-fold (0.14 log units) above it; the measured number falls inside the stated range.
By their numbers in this assay, from the lowest: compounds 3, 1 and 2 (each within the scatter of the next).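

Among these compounds, compound 3 gives the first look at the aromatic carbon between two ring nitrogen atoms, since compounds 1 and 2 both carry hydrogen there and differ only in where their one chloro sits on the shared core. In this assay, placing a chloro on this carbon in place of hydrogen gives a 1.9-fold lower number from compound 2 to compound 3 (0.27 log units; within the scatter), a step within the scatter, so compound 2 and compound 3 cannot be told apart, and this single change shows that the position can carry a chloro without the reading moving clear of compound 2. No separate measurement is available to explain this reading, and one pair of compounds sets no general rule for the position.

As far as these compounds go, what stays open is whether a different group on this carbon, such as an amine, a methoxy group or a longer chain, would also leave the reading within the scatter or would move it clearly in either direction. From the compounds shown here alone, it is also open whether a chloro on the same carbon would give a similar step on the core of compound 1, where the other chloro sits elsewhere.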